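The source may hold more compounds than are shown below. What is called first, only, known or untested is meant among the compounds shown, and "the series" means these compounds.

Measured compounds:
Compound 1, `CN1CCN(CC(=O)OC2CC3(N(C)C)CC(c4ccccc4)C2C(c2ccccc2)C3)CC1`, in an ADME assay on L6 cells (Rattus norvegicus) for cytotoxicity, read by resazurin assay, with a stated time of 72 h (a higher number here means a weaker inhibitor, a lower number a stronger inhibitor), compound 1 gives 39900 nM.
Compound 2, `CN1CCN(CCC(=O)NC2CC3(N(C)C)CC(c4ccccc4)C2C(c2ccccc2)C3)CC1`, compound 2 gives 95000 nM.
Compound 3, `CN1CCN(CC(=O)OC2CC3(N4CCCC4)CC(c4ccccc4)C2C(c2ccccc2)C3)CC1`, compound 3 gives 24600 nM.

Compound 3 has the lowest of the three numbers. Within the data shown here, its nearest neighbour is compound 1, and the only single-point step among the measured compounds, a 1.6-fold lower number from compound 1 to compound 3 (0.21 log units; within the scatter), lies within the scatter. Among the measured compounds shown here, compound 2 stands furthest from compound 3, beyond the scatter, but it differs from compound 1 and compound 3 in more than one place, so its values show only a gap and no single step.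

Compound 4, `NCC(=O)OC1CC2(N3CCCC3)CC(c3ccccc3)C1C(c1ccccc1)C2`, is not yet measured. It differs from compound 3 as follows: amino in place of 4-methylpiperazin-1-yl on a saturated chain carbon bound to a carbonyl carbon. For the measured compounds named here, no measured step touches the 4-methylpiperazin-1-yl group, so nothing measured bears directly on this change. Going by the values given here, the one measured step, from compound 1 to compound 3, was within the scatter, and the account therefore expects no step beyond the scatter in this assay: a 1.2-fold higher number from compound 3 to compound 4 (0.09 log units; within the scatter). For compound 4 the expected value is 30000 nM, between 10000 nM and 90000 nM.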

Compound 4, half-maximal inhibitory concentration: 42900 nM
Beside the measured number, compound 4's estimate is 1.4-fold (0.16 log units) below it; the measured number falls inside the stated range.
By their numbers in this assay, from the lowest: compounds 3, 1 and 4 (each within the scatter of the next); then compound 2.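

Among these compounds, the place on a saturated chain carbon bound to a carbonyl carbon is now covered by a measured step: in this assay, amino in place of 4-methylpiperazin-1-yl gives a 1.7-fold higher number from compound 3 to compound 4 (0.24 log units; within the scatter), the first reading of a change at this place. In this one pair, the six-membered non-aromatic ring with its 2 hetero atoms gives way to a single nitrogen without a step beyond the scatter, so this assay does not separate the two groups here. Nothing available accounts for this result.

From the compounds shown here alone, it remains open whether other groups at this place, such as morpholin-4-yl, dimethylamino or a carboxylic acid, would also stay within the scatter. Going by these compounds, it is also open whether amino would read the same way with dimethylamino rather than pyrrolidin-1-yl on the saturated ring carbon.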